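The source may report more compounds than this note shows. Statements on the series, on what has been measured and on what is new or still open speak of the compounds shown alone.

Measured in a functional assay on MCF7 cells (Homo sapiens) for antiproliferative activity, read by MTT assay, with a stated time of 48 h; a lower number here means a stronger inhibitor, a higher number a weaker inhibitor:
- Compound 1 `CC(=O)OC/C1=C/C[C@](C)(CCC=C(C)C)/C=C/[C@@H](OC(=O)C=C(C)C)[C@](C)(O)/C=C/C1=O`: 4510 nM
- Compound 2 `COCOC/C1=C/C[C@](C)(CCC=C(C)C)/C=C/[C@@H](OC(=O)C=C(C)C)[C@](C)(O)/C=C/C1=O`: 3120 nM
- Compound 3 `CSC(=S)OC/C1=C/C[C@](C)(CCC=C(C)C)/C=C/[C@@H](OC(=O)C=C(C)C)[C@](C)(O)/C=C/C1=O`: 900 nM

Of these three, compound 3 gives the lowest number, at 900 nM. It lies beyond the scatter from both others, as shown by a 5.0-fold lower number from compound 1 to compound 3 (0.70 log units; beyond the scatter) and a 3.5-fold lower number from compound 2 to compound 3 (0.54 log units; beyond the scatter). Compound 1 and compound 2 differ only within the scatter, as a 1.4-fold lower number from compound 1 to compound 2 (0.16 log units; within the scatter) shows.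

Compound 4 `CC(C)=CCC[C@]1(C)/C=C/[C@@H](OC(=O)C=C(C)C)[C@](C)(O)/C=C/C(=O)/C(C(=O)N(C(C)C)C(C)C)=C\C1` has not yet been measured. The change is a group of 9 heavy atoms (7 carbon, 1 nitrogen, 1 oxygen; no ring) in place of a group of 6 heavy atoms (3 carbon, 1 oxygen, 2 sulfur; no ring), on a double-bonded ring carbon: a diisopropylcarbamoyl group stands on a double-bonded ring carbon, in place of the group of compound 3.

Among the compounds with values here, no measured step makes this change, since all three alter only a group on an oxygen on a saturated carbon. Still, the modest 3.5-fold lower number from compound 2 to compound 3 (0.54 log units; beyond the scatter) went with the group that compound 4 gives up, so a modest move back towards a higher number is expected. The expected step in this assay is a 3.3-fold higher number from compound 3 to compound 4 (0.52 log units; beyond the scatter), and it is an uncertain estimate. For compound 4 the estimated value is 3000 nM, with an expected range of 1000 nM to 9000 nM.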

Compound 4, half-maximal inhibitory concentration: 17200 nM
Beside the measured number, compound 4's estimate is 5.7-fold (0.76 log units) below it; measured number outside the range, above it.
By their numbers in this assay, from the lowest: compound 3; then compounds 2 and 1 (each within the scatter of the next); then compound 4.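

In this assay the diisopropylcarbamoyl group, set directly on the double-bonded ring carbon, gives a 19-fold higher number from compound 3 to compound 4 (1.28 log units; beyond the scatter) and a 5.5-fold higher number from compound 2 to compound 4 (0.74 log units; beyond the scatter) and a 3.8-fold higher number from compound 1 to compound 4 (0.58 log units; beyond the scatter) as its steps, all beyond the scatter. The earlier compounds shown here changed only the group on the oxygen on a saturated carbon, whereas this change replaces the whole substituent on the ring carbon and shows that such a replacement can raise the number above that of all three oxygen-bearing compounds. No measurement given here accounts for this rise.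

With only one amide shown, the compounds leave open whether the diisopropyl groups or the amide itself goes with the higher number. A dimethylcarbamoyl group, an unsubstituted carbamoyl group or a carboxylic acid on the same ring carbon would help to separate the two.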